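The source may hold more compounds than are shown below. What is called first, only, known or untested is meant among the compounds shown, and "the series" means these compounds.

compound 1 `CN1C[C@H](C(=O)Nc2ccccc2)[C@@H](c2ccc(/C=C/C(=O)Nc3ccccc3N)cc2)C1`: 7 mL/min/kg
compound 2 `CN1C[C@H](C(=O)Nc2ccc(C3CC3)cc2)[C@@H](c2ccc(/C=C/C(=O)Nc3ccccc3N)cc2)C1`: 12 mL/min/kg
compound 3 `CN1C[C@H](C(=O)Nc2ccccc2F)[C@@H](c2ccc(/C=C/C(=O)Nc3ccccc3N)cc2)C1`: 10 mL/min/kg

In an in vitro ADME assay on microsomes from liver (Homo sapiens) for pharmacokinetics, read by LC-MS, with a stated time of 10 min, tested at 1 uM (on this read-out higher numbers stand for fast clearance and lower numbers for slow clearance), compound 1 gives the lowest of the three numbers, though both of the others lie within the scatter of it: compound 3 is the nearest and compound 2 the furthest. Compound 4 `CN1C[C@H](C(=O)Nc2ccc(F)c(Cl)c2)[C@@H](c2ccc(/C=C/C(=O)Nc3ccccc3N)cc2)C1` differs from compound 1 in one place: 3-chloro-4-fluorophenyl in place of phenyl on an amide-type nitrogen. Among the compounds with values here, two measured steps bear on this change, since each likewise places a group on an aromatic carbon of the phenyl: a 1.7-fold higher number from compound 1 to compound 2 (0.23 log units; within the scatter) and a 1.4-fold higher number from compound 1 to compound 3 (0.15 log units; within the scatter). Neither reached beyond the scatter, so in this assay no step beyond the scatter is expected from compound 1 to compound 4, with a small rise the most that seems likely. Compound 4 is therefore estimated at 11 mL/min/kg in this assay, with a range of 6 mL/min/kg to 22 mL/min/kg. The expected step is a 1.6-fold higher number from compound 1 to compound 4 (0.20 log units; within the scatter).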

Compound 4, clearance: 15 mL/min/kg
Compound 4: middle estimate off by 1.4-fold (0.13 log units), on the low side; the range from low to high includes it.
By their numbers in this assay, from the lowest: compounds 1, 3, 2 and 4 (each within the scatter of the next, the first and the last beyond it).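

In this assay, within the data shown here, the change to 3-chloro-4-fluorophenyl on the amide-type nitrogen gives a 2.1-fold higher number from compound 1 to compound 4 (0.33 log units; beyond the scatter) and so is the only change here at this position to pass the scatter, though modestly. Compound 4 stays within the scatter of the other substituted rings, with a 1.5-fold higher number from compound 3 to compound 4 (0.18 log units; within the scatter) and also a 1.3-fold higher number from compound 2 to compound 4 (0.10 log units; within the scatter) as its steps. No measurement offered here explains this step.
The compounds shown leave open whether the chloro or the fluoro group alone would give such a step, and how a pyridyl ring or an amine on the phenyl would read.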